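Benzyl substituent variation on the indole nitrogen of the urea series

The source may hold more compounds than are shown below. What is called first, only, known or untested is meant among the compounds shown, and "the series" means these compounds.

All three measured compounds share a core in which a diethylaminomethyl-substituted benzothiazole urea is linked through a hydrazone to an indole; they differ only at the indole nitrogen. Compound 1 `CCN(CC)Cc1ccc2nc(NC(=O)N/N=C/c3cn(Cc4ccccc4Cl)c4ccccc34)sc2c1` gives 1390 nM in a functional assay on A549 cells (Homo sapiens) for cytotoxicity, read by MTT assay, with a stated time of 72 h; on this read-out higher numbers stand for weaker inhibition and lower numbers for stronger inhibition. Compound 2 `CCN(CC)Cc1ccc2nc(NC(=O)N/N=C/c3c[nH]c4ccccc34)sc2c1`, with hydrogen at that nitrogen, gives 3300 nM. Compound 3 `CCN(CC)Cc1ccc2nc(NC(=O)N/N=C/c3cn(Cc4ccc(C)cc4)c4ccccc34)sc2c1`, carrying a 4-methylbenzyl group, gives 1510 nM, the second highest of the three numbers: it sits within the scatter of compound 1 and beyond the scatter of compound 2. The measured steps show a 2.4-fold higher number from compound 1 to compound 2 (0.38 log units; beyond the scatter), a 2.2-fold lower number from compound 2 to compound 3 (0.34 log units; beyond the scatter) and a 1.1-fold higher number from compound 1 to compound 3 (0.04 log units; within the scatter).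

Compound 4 `CCN(CC)Cc1ccc2nc(NC(=O)N/N=C/c3cn(Cc4cccc(Cl)c4)c4ccccc34)sc2c1` differs from compound 3 by 3-chlorophenyl in place of 4-methylphenyl on a saturated chain carbon bound to an aromatic nitrogen. The step that bears most directly on this is the exchange of one substituted benzyl for another, a 1.1-fold higher number from compound 1 to compound 3 (0.04 log units; within the scatter), which stayed within the scatter; the two larger steps concern adding or removing the whole benzyl group, which compound 4 keeps. No step beyond the scatter is therefore expected in this assay, and the estimate for compound 4 is 1450 nM, between 700 nM and 3000 nM. The expected step is a 1.0-fold lower number from compound 3 to compound 4 (0.02 log units; within the scatter).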

Compound 4, half-maximal inhibitory concentration: 2410 nM
Compound 4: the middle estimate sits 1.7-fold (0.22 log units) below what was measured; low and high end bracket the measured number.
By their numbers in this assay, from the lowest: compounds 1, 3, 4 and 2 (each within the scatter of the next, the first and the last beyond it).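

In this assay, a 1.6-fold higher number from compound 3 to compound 4 (0.20 log units; within the scatter) and a 1.7-fold higher number from compound 1 to compound 4 (0.24 log units; within the scatter), both within the scatter, so the three substituted benzyl groups on the aromatic nitrogen cannot be told apart by this read-out, including the 3-chlorophenyl and 2-chlorophenyl pair. What compound 4 adds is a 1.4-fold lower number from compound 2 to compound 4 (0.14 log units; within the scatter), also within the scatter, whereas a 2.4-fold higher number from compound 1 to compound 2 (0.38 log units; beyond the scatter) and a 2.2-fold lower number from compound 2 to compound 3 (0.34 log units; beyond the scatter) both lie beyond it; the separation from the unsubstituted compound 2 therefore holds for compounds 1 and 3, compound 4 goes against it, and having a benzyl group at this nitrogen does not by itself separate a compound from compound 2. No measurement available here accounts for this difference among the benzyl compounds.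

The compounds shown leave open how a substituent without an aromatic ring, such as a longer alkyl chain, would compare with the benzyl groups on this nitrogen. They also leave open what a benzyl group carrying an amine or a carboxylic acid would give, and whether any such group would move the number beyond the scatter of compounds 1, 3 and 4.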